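This account rests on a few compounds, and the source may have more. Where it says the series, first, only, none or still open, it means among the compounds named here.

Going by the values given here, compound 2 `Cn1ccc(S(=O)(=O)Nc2cccc(NC(=O)COc3ccc4c(=O)ccoc4c3)c2)n1` stands highest of the two numbers so far in an assay on isolated protein for inhibition of Rho-associated protein kinase 2 (Homo sapiens), read by scintillation counting, radiometric assay and 33P incorporation, with a stated time of 40 min, in the presence of a further agent that is not named here (a higher number here means a weaker inhibitor, a lower number a stronger inhibitor), where compound 2 gives 1350 nM. Its nearest neighbour is compound 1 `O=C(COc1ccc2c(=O)ccoc2c1)Nc1cccc(NC(=O)c2cccc([N+](=O)[O-])c2)c1`, which in this assay gives 41 nM. Among the compounds with values here, the step of a 33-fold higher number from compound 1 to compound 2 (1.52 log units; beyond the scatter) is the only measured step in the set; it exchanged a six-membered carbon-only aromatic ring joined through a carbonyl for a five-membered aromatic ring with 2 hetero atoms joined through sulfur, on the same ring nitrogen. Compound 3 `Nc1cccc(C(=O)Nc2cccc(NC(=O)COc3ccc4c(=O)ccoc4c3)c2)c1` goes the other way: a group of 9 heavy atoms (7 carbon, 1 nitrogen, 1 oxygen; one six-membered aromatic ring of carbon only) in place of a group of 9 heavy atoms (4 carbon, 2 nitrogen, 2 oxygen, 1 sulfur; one five-membered aromatic ring with 2 hetero atoms), on a nitrogen on an aromatic ring. This reinstates a six-membered carbon-only aromatic ring joined through a carbonyl to that nitrogen, the arrangement compound 1 has, so the step from compound 1 to compound 2 bears directly on it, run in reverse. Within the data shown here, the ring substituent of compound 3 is not that of compound 1, and no measured pair shows what that difference alone does, so part of the step size stays open. A large fall is expected, a 19-fold lower number from compound 2 to compound 3 (1.29 log units; beyond the scatter), though not necessarily back to the level of compound 1. Compound 3 is estimated at 70 nM, range 15 nM to 300 nM.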

Compound 3, half-maximal inhibitory concentration: 58 nM
Compound 3: middle estimate off by 1.2-fold (0.08 log units), on the high side, and the stated range covers the measured number.
By their numbers in this assay, from the lowest: compounds 1 and 3 (each within the scatter of the next); then compound 2.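

In this assay, the (3-aminophenyl)carbonyl group on the nitrogen gives a 23-fold lower number from compound 2 to compound 3 (1.37 log units; beyond the scatter) and so places compound 3 with compound 1 rather than with compound 2. The step of a 1.4-fold higher number from compound 1 to compound 3 (0.15 log units; within the scatter) is amino in place of nitro on an aromatic carbon and lies within the scatter, so the nitro group is not needed for a number at this level, and two quite different substituents on the six-membered carbon-only ring give values that cannot be told apart. Across these three compounds, the low numbers go with a six-membered carbon-only aromatic ring joined through a carbonyl, with no compound shown going against this, and no measurement at hand explains either step.

Compound 2 differs from the other two in both the ring and its link, so the part played by the sulfonyl link and the part played by the five-membered ring remain unseparated; a phenylsulfonyl group or a five-membered ring joined through a carbonyl would divide them. How far the ring substituent can vary also stays open, since only amino and nitro are shown, and a hydrogen, a methoxy group or a carboxylic acid in that place could still shift the number.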